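The compounds below may be only part of what the source reports. "The series", "measured", "known", "first", "only" and "open" are said of these compounds alone.

Measured in a toxicity assay on L02 cells (Homo sapiens) for cytotoxicity, read by MTT assay, with a stated time of 72 h; on this read-out higher numbers stand for weaker inhibition and lower numbers for stronger inhibition:
compound 1 `CN1CCN(CCCCCCn2c3c(c4ccccc42)C(=O)c2c[n+]([O-])c4ccccc4c2C3=O)CC1` gives 3800 nM;
compound 2 `CC1(C)O[C@@H](CO)[C@H](Cn2cc(Cn3c4c(c5ccccc53)C(=O)c3c[n+]([O-])c5ccccc5c3C4=O)nn2)O1` gives 500 nM;
compound 3 `CCCCN1CCN(CCCCn2c3c(c4ccccc42)C(=O)c2c[n+]([O-])c4ccccc4c2C3=O)CC1` gives 5690 nM.

Compound 2 has the lowest number of the three in this assay; compound 1 and compound 3 both sit well above it, and the gaps from compound 2 to each of them are beyond the scatter. For the measured compounds named here, the only step between neighbours that differ in one place is a 1.5-fold higher number from compound 1 to compound 3 (0.18 log units; within the scatter), a change on the saturated chain, far from the part of the molecule altered here.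

Compound 4 `O=C1c2c[n+]([O-])c3ccccc3c2C(=O)c2c1c1ccccc1n2Cc1cn([C@@H]2O[C@H](CO)[C@@H](O)[C@H](O)[C@H]2O)nn1` differs from compound 2 by 3,4,5-trihydroxy-6-(hydroxymethyl)oxan-2-yl in place of (5-(hydroxymethyl)-2,2-dimethyl-1,3-dioxolan-4-yl)methyl on an aromatic nitrogen. Going by the values given here, no measured step touches the group on the triazole nitrogen, so nothing among the three measurements bears directly on this change, and no direction for this assay can be read from them. The working expectation is a step of about a 1.6-fold higher number from compound 2 to compound 4 (0.20 log units; within the scatter), that is, a number close to that of compound 2 with a broad range to either side. Compound 4 is therefore estimated at 800 nM in this assay, between 200 nM and 3000 nM.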

Compound 4, half-maximal inhibitory concentration: 420 nM
The estimate for compound 4 lay 1.9-fold (0.28 log units) above the measured number; the measured number falls inside the stated range.
By their numbers in this assay, from the lowest: compounds 4 and 2 (each within the scatter of the next); then compounds 1 and 3 (each within the scatter of the next).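

In this assay, for the compounds shown here, 3,4,5-trihydroxy-6-(hydroxymethyl)oxan-2-yl in place of (5-(hydroxymethyl)-2,2-dimethyl-1,3-dioxolan-4-yl)methyl on an aromatic nitrogen gives a 1.2-fold lower number from compound 2 to compound 4 (0.08 log units; within the scatter), the first reading of a change at this position, and that step cannot be told from the scatter. The exchange is a sizeable one on paper: a six-membered ring replaces a five-membered one, with 4 hydrogen-bond donors instead of 1 and 5 defined stereocentres instead of 2, yet the read-out does not separate the two compounds. Nothing measured on hand accounts for this result.

Open, going by these compounds, is whether the same holds for a group of another kind on this nitrogen, such as a primary amine or a carboxylic acid. Also open is whether the arrangement of the stereocentres on the oxan-2-yl group matters, as only one arrangement is shown.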